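The compounds below may be only part of what the source reports. "The series", "measured", "known", "first", "only" and "open" are said of these compounds alone.

Measured in a functional assay on MIA PaCa-2 cells (Homo sapiens) for inhibition, read by MTT assay, with a stated time of 7 days; on this read-out higher numbers stand for weaker inhibition and lower numbers for stronger inhibition:
Compound 1 `CCOC(=O)[C@@H]1CCCN(S(=O)(=O)c2ccc(S(=O)(=O)N3CCOCC3)cc2)C1`: 23500 nM
Compound 2 `CCOC(=O)[C@@H]1CCCN(S(=O)(=O)c2ccc(S(=O)(=O)N(C)C)cc2)C1`: 900 nM

Compound 2 holds the lower of the two numbers and is thus the stronger inhibitor of the pair. The next compound, compound 3 `CCOC(=O)[C@@H]1CCCN(S(=O)(=O)c2ccc(C(=O)N(CC)CC)cc2)C1`, has not yet been measured in this assay. It carries diethylcarbamoyl in place of dimethylsulfamoyl on an aromatic carbon. Among the compounds with values here, only one measured step bears on this change. That step, a 26-fold lower number from compound 1 to compound 2 (1.42 log units; beyond the scatter), is large and beyond the scatter, and it put dimethylamino in place of morpholin-4-yl on a sulfonyl sulfur. Within the data shown here, it shows that this substituent can matter a great deal, but no measured compound lacks the sulfonyl group, so the direction remains uncertain. A moderate move towards weaker inhibition is expected, though not firmly. The expected step is a 2.2-fold higher number from compound 2 to compound 3 (0.35 log units; beyond the scatter). For compound 3 the estimated value is 2000 nM, with an expected range of 450 nM to 10000 nM.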

Compound 3, half-maximal inhibitory concentration: 800 nM
Estimate against measurement, compound 3: 2.5-fold (0.40 log units) above; the range from low to high includes it.
By their numbers in this assay, from the lowest: compounds 3 and 2 (each within the scatter of the next); then compound 1.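

In this assay, diethylcarbamoyl in place of dimethylsulfamoyl on this aromatic carbon gives a step within the scatter (a 1.1-fold lower number from compound 2 to compound 3 (0.05 log units; within the scatter)), so the sulfonyl group of compound 2 is not needed at this position to keep that level of inhibition. Set against (morpholin-4-yl)sulfonyl, the same diethylcarbamoyl gives a large step (a 29-fold lower number from compound 1 to compound 3 (1.47 log units; beyond the scatter)), which leaves compound 1 apart from the other two compounds shown. Nothing measured here explains how these groups compare.

The compounds shown leave open whether morpholin-4-ylcarbonyl on this carbon would give a number close to that of compound 1 or close to that of compound 3. Also open, on these data alone, is what a carboxylic acid or a primary amine at this place would give.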